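Methyl on the phenoxy group of compound 1

This account rests on a few compounds, and the source may have more. Where it says the series, first, only, none or still open, it means among the compounds named here.

In a functional assay on MCF7 cells (Homo sapiens) for inhibition, read by MTT assay, with a stated time of 24 h (on this read-out lower numbers stand for stronger inhibition and higher numbers for weaker inhibition), compound 1 `O=C1CSC(c2c[nH]nc2-c2ccc(F)cc2)N1n1c(S)nnc1COc1ccccc1` gives 30 ug/mL, the lowest of the three numbers in hand. Compound 3 `COc1ccc(-c2n[nH]cc2C2SCC(=O)N2n2c(S)nnc2COc2ccccc2)cc1` gives 85 ug/mL and compound 2 `O=C1CSC(c2c[nH]nc2-c2ccc(Cl)cc2)N1n1c(S)nnc1COc1ccc2ccccc2c1` gives 100 ug/mL.

The next compound is compound 4 `Cc1ccccc1OCc1nnc(S)n1N1C(=O)CSC1c1c[nH]nc1-c1ccc(F)cc1`, and its change is methyl in place of hydrogen on an aromatic carbon, ortho to a large group, which turns phenoxy to 2-methylphenoxy.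

For the measured compounds named here, only one measured step changes a single place, a 2.8-fold higher number from compound 1 to compound 3 (0.45 log units; beyond the scatter). That step is modest and beyond the scatter, but it is methoxy in place of fluoro, not a change at the phenoxy group, so it bears on this case only indirectly. Going by the values given here, no measured step tests methyl on the phenoxy group. Among the compounds with values here, the expected move in this assay is therefore small, leaning to a higher number, since compound 1 holds the lowest value so far. The estimated step is a 1.3-fold higher number from compound 1 to compound 4 (0.12 log units; within the scatter), expected to stay within the scatter. Compound 4 is estimated at 40 ug/mL, with an expected range of 18 ug/mL to 90 ug/mL.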

Compound 4, half-maximal inhibitory concentration: > 100 ug/mL
Compound 4: a limit, no number; the forecaster's own chance of this, stated with the estimate: 5%; middle value at least 2.5-fold (0.39 log units) from the limit.
By their numbers in this assay, from the lowest: compound 1; then compounds 3 and 2 (each within the scatter of the next).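

In this assay compound 4 gives > 100 ug/mL, a limit of the assay and not a number: the limit of > 100 ug/mL in this assay, at which 1 of the 4 values shown sits.

Methyl in place of hydrogen on the phenoxy ring, ortho to a large group, gives an at least 3.3-fold higher number from compound 1 to compound 4 (0.52 log units; beyond the scatter), so this ring position responds to a single added carbon. For the compounds shown here, the only earlier single-place step, a 2.8-fold higher number from compound 1 to compound 3 (0.45 log units; beyond the scatter), was methoxy in place of fluoro and left the phenoxy group untouched.

The compounds shown do not separate the effect of this place on the ring from that of methyl as such, since none carries methyl at another place on the phenoxy ring. Going by these compounds, how an amine or a hydroxyl at the same place would read in this assay also stays open.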